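Carbamate selenium compounds: propyl to isobutyl on a selenocyanate

This account rests on a few compounds, and the source may have more. Where it says the series, first, only, none or still open, it means among the compounds named here.

Measured compounds:
compound 1 `CC(C)COC(=O)Nc1ccc([Se][Se]c2ccc(NC(=O)OCC(C)C)cc2)cc1` gives 77400 nM
compound 2 `CCCOC(=O)Nc1ccc([Se]C#N)cc1` gives 75400 nM
compound 3 `O=C(Nc1ccc([Se][Se]c2ccc(NC(=O)Oc3ccccc3)cc2)cc1)Oc1ccccc1` gives 70200 nM

In a functional assay on HT-29 cells (Homo sapiens) for cytotoxicity, read by MTT assay, with a stated time of 72 h (a higher number here means that more compound is tolerated, a lower number that less compound is tolerated), the three measured compounds sit close together: compound 1 gives 77400 nM, compound 2 gives 75400 nM, and compound 3 gives 70200 nM. Compound 2 stands with compound 1 and compound 3 within the usual scatter of one another, so none of the three can be set apart from the others on these numbers. Both diselenides, compound 1 with an isobutyl carbamate and compound 3 with a phenyl carbamate, show values no different in practice from that of the propyl selenocyanate compound 2.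

Compound 4 `CC(C)COC(=O)Nc1ccc([Se]C#N)cc1` has not yet been measured. It differs from compound 2 by methyl in place of hydrogen on a saturated chain carbon bound to two saturated chain carbons, which read one bond further out is propyl to isobutyl, or propoxy to isobutoxy. Among the measured compounds shown here, no step between measured compounds that differ in one place is available here, so the expectation rests on the spread of the three values, which is flat. The step from compound 2 to compound 4 is therefore expected to be small, a 1.0-fold lower number from compound 2 to compound 4 (0.00 log units; within the scatter), with no direction beyond the scatter. Compound 4 is estimated at 75000 nM, within a range from 40000 nM to 140000 nM.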

Compound 4, concentration lethal to 50% of the cells: 63700 nM
Compound 4: the middle estimate sits 1.2-fold (0.07 log units) above what was measured, within the range that was stated.
By their numbers in this assay, from the lowest: compounds 4, 3, 2 and 1 (each within the scatter of the next).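

In this assay, among the compounds shown here, the new pair gives the first direct reading of this position: with the selenocyanate and the rest of the compound held the same, methyl in place of hydrogen on a saturated chain carbon bound to two saturated chain carbons amounts to a 1.2-fold lower number from compound 2 to compound 4 (0.07 log units; within the scatter). The earlier compounds shown here could not show this, since none of them differs from another in one place, and their close values said nothing about any single change. For this one pair, then, propyl to isobutyl on the carbamate leaves the two compounds indistinguishable in this read-out, and nothing shown gives an explanation for that.

From the compounds shown here alone, it remains open whether a longer chain, or an amine or a carboxylic acid on the chain, would carry the number beyond the scatter at this place. Going by these compounds, it is also open whether propyl to isobutyl would read the same way on a diselenide, so this result cannot yet be taken as a rule beyond compound 2 and compound 4.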